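Bromo for chloro on the aryl ring of compound 3

The source may hold more compounds than are shown below. What is called first, only, known or untested is meant among the compounds shown, and "the series" means these compounds.

The series shares one core, carrying a 4-chlorobenzyl arm and an aryl ring, and is tested in a functional assay on HeLa cells (Homo sapiens) for cytotoxicity, with a stated time of 72 h; a higher number here means a weaker inhibitor, a lower number a stronger inhibitor. Compound 1 `Clc1ccc(Cc2nn3cc(-c4ccc(Br)cc4)nc3s2)cc1` gives only a limit, > 250000 nM. Compound 2 `Clc1ccc(Cc2nn3c(Br)c(-c4ccc(Br)cc4)nc3s2)cc1` gives 188000 nM in this assay, and compound 3 `O=Cc1c(-c2ccc(Cl)cc2)nc2sc(Cc3ccc(Cl)cc3)nn12` gives 16000 nM. Among the two numbers compound 3 stands lowest, with compound 2 the nearest, a gap beyond the scatter. Compound 4 `O=Cc1c(-c2ccc(Br)cc2)nc2sc(Cc3ccc(Cl)cc3)nn12` differs from compound 3 only in that (bromo in place of chloro on an aromatic carbon), on an aromatic carbon of a six-membered aromatic ring of carbon only, para to a large group; read one bond further out, 4-chlorophenyl becomes 4-bromophenyl. Going by the values given here, no measured pair exchanges chloro for bromo. Among the compounds with values here, the only step touching a bromo is an at least 1.3-fold lower number from compound 1 to compound 2 (0.12 log units; that floor lies within the scatter), and it rests on a limit, (the limit of > 250000 nM in this assay, at which 1 of the 3 values shown sits). A halogen swap of this kind is therefore expected to give no step beyond the scatter, no change at the digits printed from compound 3 to compound 4 (within the scatter). Compound 4 is thus estimated at 16000 nM in this assay, within 6000 nM to 40000 nM.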

Compound 4, half-maximal inhibitory concentration: 4200 nM
For compound 4 the middle estimate is 3.8-fold (0.58 log units) above the measured one, outside the stated range (below it).
By their numbers in this assay, from the lowest: compound 4; then compound 3; then compound 2. At a limit, above all of these: compound 1.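

Going by these compounds alone, with the formyl group in place, the aromatic carbon para to a large group proves sensitive to the halogen in this assay: bromo in place of chloro gives a 3.8-fold lower number from compound 3 to compound 4 (0.58 log units; beyond the scatter), the first measured step at this position. With the 4-bromophenyl held fixed, the formyl group accounts for much larger steps, a 45-fold lower number from compound 2 to compound 4 (1.65 log units; beyond the scatter) and an at least 59-fold lower number from compound 1 to compound 4 (1.77 log units; beyond the scatter), so the halogen swap adds a modest step to two large ones. The second of these large steps is only a floor, since compound 1 gives a limit and not a number: the limit of > 250000 nM in this assay, at which 1 of the 4 values shown sits.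

On these data alone, whether bromo for chloro gives a similar step with hydrogen or bromo in place of the formyl remains open, as the 4-chlorophenyl appears only alongside the formyl. Also open, as far as these compounds go, is how an iodo or methoxy on the aryl ring, or a carboxylic acid or hydroxymethyl in place of the formyl, would read here.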